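The source may report more compounds than this note shows. Statements on the series, on what has been measured and on what is new or still open speak of the compounds shown alone.

Values in a functional assay on T47D cells (Homo sapiens) for inhibition, read by CCK-8 assay, with a stated time of 72 h, tested at 1 uM; on this read-out lower numbers stand for less inhibition of growth and higher numbers for more inhibition of growth at the one concentration tested:

compound 1 `CN(C)C(=O)c1cc2cnc(Nc3ccc(NC(=O)C4(C(=O)Nc5ccc(F)cc5)CC4)cc3)nc2n1C1CCCC1`: 74.7%
compound 2 `Cc1cccc(NC(=O)C2(C(=O)Nc3ccc(Nc4ncc5cc(C(=O)N(C)C)n(C6CCCC6)c5n4)cc3)CC2)c1`: 45.7%
compound 3 `COc1cccc(NC(=O)C2(C(=O)Nc3ccc(Nc4ncc5cc(C(=O)N(C)C)n(C6CCCC6)c5n4)cc3)CC2)c1`: 56.3%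

Compound 1 stands highest of the three; the nearest is compound 3, the step being a number 18.4 percentage points lower from compound 1 to compound 3 (beyond the scatter), and the furthest is compound 2, with a number 29 percentage points lower from compound 1 to compound 2 (beyond the scatter). Between the two lower compounds the step is a number 10.6 percentage points higher from compound 2 to compound 3 (beyond the scatter).

Compound 4 `CN(C)C(=O)c1cc2cnc(Nc3ccc(NC(=O)C4(C(=O)Nc5cccc(Br)c5)CC4)cc3)nc2n1C1CCCC1` is not yet measured. The change from compound 1 is 3-bromophenyl in place of 4-fluorophenyl on an amide-type nitrogen. The two measured steps that replace the 4-fluorophenyl with a 3-substituted phenyl both bear on it, a number 29 percentage points lower from compound 1 to compound 2 (beyond the scatter) and a number 18.4 percentage points lower from compound 1 to compound 3 (beyond the scatter), each a modest loss beyond the scatter. A modest loss is therefore expected here too, a number 19.7 percentage points lower from compound 1 to compound 4 (beyond the scatter). For compound 4 the estimate in this assay is 55%, within 35% to 75%.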

Compound 4, percent growth inhibition at one concentration: 29.1%
Compound 4: the middle estimate sits 25.9 percentage points above what was measured; the whole stated range lies above it.
By their numbers in this assay, from the lowest: compound 4; then compound 2; then compound 3; then compound 1.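

Working from the amide-type nitrogen, 3-bromophenyl gives the largest loss seen at this position, with a number 45.6 percentage points lower from compound 1 to compound 4 (beyond the scatter) as the step. The identity of the group on the 3-substituted phenyl also matters, with a number 27.2 percentage points lower from compound 3 to compound 4 (beyond the scatter) and a number 16.6 percentage points lower from compound 2 to compound 4 (beyond the scatter) placing bromo below both methoxy and methyl. Nothing available accounts for this ordering.

This change swaps both the halogen and its place on the phenyl ring, and the compounds shown do not separate the two. Going by these compounds, how an amine or a carboxylic acid on that ring would read also remains open.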